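The source may hold more compounds than are shown below. What is called first, only, known or untested is meant among the compounds shown, and "the series" means these compounds.

Measured so far:
Compound 1, `CCOC(=O)c1ccnc(-c2ccc(OCC)cc2)c1`: 80000 nM
Compound 2, `CCNS(=O)(=O)c1cccc(-c2ccc(OCC)cc2)c1`: 200000 nM

Of the compounds shown here, two have been tested in an assay on COS-7 cells for inhibition of patatin-like phospholipase domain-containing protein 2 (Mus musculus); a higher number here means a weaker inhibitor, a lower number a stronger inhibitor. Compound 1, `CCOC(=O)c1ccnc(-c2ccc(OCC)cc2)c1`, gives 80000 nM in this assay. Compound 2, `CCNS(=O)(=O)c1cccc(-c2ccc(OCC)cc2)c1`, gives 200000 nM in this assay. Of these two numbers, compound 2 stands higher; the gap to compound 1 lies beyond the usual scatter, so compound 2 is the weaker inhibitor of the pair. Both numbers are high, meaning neither compound inhibits the enzyme strongly.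

Compound 3, `CCOc1ccc(-c2cccc(C)c2)cc1`, has not yet been measured. Compared with compound 2 the change is methyl in place of ethylsulfamoyl on an aromatic carbon. Among the compounds with values here, no step between two measured compounds describes a change of this kind, so the direction has to be guessed. Stripping the ethylsulfamoyl down to a methyl leaves a bare biaryl with only an ethoxy group, and a compound this simple is expected to be no stronger than compound 2. The step from compound 2 to compound 3 is estimated at a 1.5-fold higher number from compound 2 to compound 3 (0.18 log units; within the scatter), with the number staying in the weak range or going higher. Compound 3 is therefore expected to give about 300000 nM in this assay, within a range from 80000 nM to 1500000 nM.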

Compound 3, half-maximal inhibitory concentration: 70000 nM
Estimate against measurement, compound 3: 4.3-fold (0.63 log units) above; measured number below the stated range.
By their numbers in this assay, from the lowest: compounds 3 and 1 (each within the scatter of the next); then compound 2.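

In this assay, replacing ethylsulfamoyl with methyl on this aromatic carbon gives a 2.9-fold lower number from compound 2 to compound 3 (0.46 log units; beyond the scatter), the first step shown between two compounds that differ in only one place. The larger group, with its 6 heavy atoms, its hydrogen-bond donor and its 2 hydrogen-bond acceptors, is therefore not required for the inhibition seen at this position, since the single carbon of a methyl gives the lower number and so the stronger inhibitor of this pair. The data offer no independent measurement that would identify which part of this exchange accounts for the step.

From the compounds shown here alone, with a single change at this position, it remains open whether the number follows the size of the group or depends on its particular atoms, and an amine, a carboxylic acid or a longer alkyl chain on the same carbon could help to separate those possibilities. Going by these compounds, the role of the ethoxy group, which stays the same in compound 2 and compound 3, is also open, as is whether a longer chain or a hydroxyl group there would shift the number.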